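The compounds below may be only part of what the source reports. "The series", "measured", "known", "first", "only" and "open" are said of these compounds alone.

Compound 2 `O=C(NC[C@H]1CCCC[C@H]1O)NC1CCN(Cc2ccn(-c3ccc(C(F)(F)F)cc3)c2)CC1` is one of two compounds with a number in an assay on HEK293 cells for displacement of a labelled ligand from melanin-concentrating hormone receptor 1 (Homo sapiens); on this read-out higher numbers stand for weaker inhibition and lower numbers for stronger inhibition. There compound 2 gives 63 nM, the lower of the two numbers, while compound 1 `O=C(NC1CCN(Cc2ccn(-c3ccc(C(F)(F)F)cc3)c2)CC1)N1CC[C@H](O)C1` gives 125 nM; the two lie within the scatter of each other, so neither can be called the stronger binder.

The step to compound 3 `O=C(NC1CCN(Cc2ccn(-c3ccc(C(F)(F)F)cc3)c2)CC1)N1CCCC(CO)C1` is 3-(hydroxymethyl)piperidin-1-yl in place of ((2-hydroxycyclohexyl)methyl)amino on a carbonyl carbon. In plain terms, the open-chain amino group that carries the hydroxycyclohexyl ring is swapped for a ring-closed piperidine that carries a hydroxymethyl arm, so the carbonyl carbon once more bears a cyclic nitrogen, much as it does in compound 1.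

Going by the values given here, only one measured step bears on this position: a 2.0-fold lower number from compound 1 to compound 2 (0.30 log units; within the scatter). That step, going the other way from a ring-closed nitrogen to an open-chain one, stayed within the scatter. Returning to a ring-closed nitrogen is therefore expected to give at most a small step, in the direction of the number seen for compound 1, and compound 3 is expected to come out at 100 nM, with a range from 40 nM to 250 nM; the expected step is a 1.6-fold higher number from compound 2 to compound 3 (0.20 log units; within the scatter).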

Compound 3, half-maximal inhibitory concentration: 23 nM
The estimate for compound 3 lay 4.3-fold (0.64 log units) above the measured number; measured number outside the range, below it.
By their numbers in this assay, from the lowest: compound 3; then compounds 2 and 1 (each within the scatter of the next).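

In this assay, going by these compounds alone, this place on the carbonyl carbon now shows a step beyond the scatter: 3-(hydroxymethyl)piperidin-1-yl in place of ((2-hydroxycyclohexyl)methyl)amino gives a 2.7-fold lower number from compound 2 to compound 3 (0.44 log units; beyond the scatter), whereas the one earlier step stayed within it. A ring-closed nitrogen on the carbonyl is also not tied to a single level of binding, as exchanging one such group, 3-hydroxypyrrolidin-1-yl, for another, 3-(hydroxymethyl)piperidin-1-yl, gives a 5.4-fold lower number from compound 1 to compound 3 (0.74 log units; beyond the scatter), which makes compound 3 the strongest binder of the three on this read-out. Nothing available here accounts for why the piperidine group gives the lowest number.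

The compounds shown leave open whether the hydroxymethyl arm matters at all, since neither a plain piperidin-1-yl group nor a piperidine carrying a longer 2-hydroxyethyl chain stands among them for comparison. From the compounds shown here alone, the entering group also has no defined stereocentre, so it remains open whether its two mirror-image forms would give the same number.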